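Imidazolyl to dimethylamino on a propargylic carbon: two cores

The compounds below may be only part of what the source reports. "The series", "measured", "known", "first", "only" and "open" are said of these compounds alone.

Compound 1 `CC(C#CCn1ccnc1)N1CCCC1=O` and compound 2 `CC(C#CCN(C)C)N1CCCC1=O` share one core; compound 3 `O=C1NCCN1CC#CCn1ccnc1` and compound 4 `CN(C)CC#CCN1CCNC1=O` share another. How the two cores differ is not broken down here. In a functional assay on the whole organism for agonist activity, with Mus musculus as the target (on this read-out lower numbers stand for an effect already at smaller amounts and higher numbers for an effect only at larger amounts of compound), compound 1 gives only a limit, > 100 mg/kg (the limit of > 100 mg/kg in this assay, at which 1 of the 3 values shown sits). In this assay compound 2 gives 6.6 mg/kg. The change between them, (dimethylamino in place of 1H-imidazol-1-yl on a saturated chain carbon bound to a triple-bonded carbon), made a step of an at least 15-fold lower number from compound 1 to compound 2 (1.18 log units; beyond the scatter). In this assay compound 3 gives 17.3 mg/kg, the highest number among the two measured numbers and beyond the scatter from compound 2.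

The change from compound 3 to compound 4 is the same change, (dimethylamino in place of 1H-imidazol-1-yl on a saturated chain carbon bound to a triple-bonded carbon), on the same kind of carbon. For compound 4 the step is expected to be an 8.7-fold lower number from compound 3 to compound 4 (0.94 log units; beyond the scatter), resting on the step seen from compound 1 to compound 2 an at least 15-fold lower number from compound 1 to compound 2 (1.18 log units; beyond the scatter), though that step rests on a limit for compound 1 and its true size is not known. In this assay compound 4 is therefore estimated at 2 mg/kg, with a range from 0.7 mg/kg to 6 mg/kg.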

Compound 4, dose for half-maximal effect: 9.7 mg/kg
For compound 4 the middle estimate is 4.9-fold (0.69 log units) below the measured one; measured number above the stated range.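

In this assay, the change to dimethylamino on the core of compound 3 gives a 1.8-fold lower number from compound 3 to compound 4 (0.25 log units; within the scatter), so on this core the exchange of 1H-imidazol-1-yl has no readable effect. The size of the step therefore did not carry over from one core to the other: the same change on two cores in this assay, an at least 15-fold lower number (1.18 log units; beyond the scatter) from compound 1 to compound 2 and a 1.8-fold lower number (0.25 log units; within the scatter) from compound 3 to compound 4, at least 8.4-fold (0.92 log units) apart, beyond the scatter of two such steps

This does not show how large the step on the core of compound 1 truly is, nor which difference between the two cores separates the steps, and the series offers only one pair on each core, with one end of the first pair resting on a limit: the limit of > 100 mg/kg in this assay, at which 1 of the 4 values shown sits.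

As far as these compounds go, it remains open whether another amine, such as diethylamino, would behave like dimethylamino on both cores, or whether the gap between the steps would persist with it. Also open, from the compounds shown here alone, is whether a longer chain carrying the same groups would bring the two steps closer together or push them further apart.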